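A few compounds are considered here, and "the series" means these few. Any claim that something is new, unique, unknown or untested is made for them only; others in the source may bear on it.

Working notes on the series. Compound 1 `CC[C@@H]1C(=O)N(C)c2cnc(Nc3ccc(S(=O)(=O)NC4CCCC4)cc3)nc2N1C1CCCC1` carries a cyclopentyl on the sulfonamide nitrogen, compound 2 `CC[C@@H]1C(=O)N(C)c2cnc(Nc3ccc(S(N)(=O)=O)cc3)nc2N1C1CCCC1` has hydrogen there, and compound 3 `CCC1C(=O)N(C)c2cnc(Nc3ccc(S(=O)(=O)NCCO)cc3)nc2N1c1ccn(C)n1` is a further sulfonamide analogue on a different core. In a functional assay on NCI-H1975 cells (Homo sapiens) for antiproliferative activity, read by CCK-8 assay, with a stated time of 72 h (a higher number here means a weaker inhibitor of growth, a lower number a stronger inhibitor of growth), compound 1 gives 1710 nM, compound 2 gives 5290 nM, and compound 3 is reported as "not active" (no number reported). Compound 2 thus stands at the higher of the two numbers, the change being a 3.1-fold higher number from compound 1 to compound 2 (0.49 log units; beyond the scatter). Compound 4 `CC[C@@H]1C(=O)N(C)c2cnc(Nc3ccc(S(=O)(=O)Nc4ccccc4)cc3)nc2N1C1CCCC1` differs from compound 2 by phenyl in place of hydrogen on a sulfonamide nitrogen. Going by the values given here, the only step that bears on this is the hydrogen-for-cyclopentyl step, which raised the number beyond the scatter; a substituent entering on the same nitrogen is expected to move the number the other way by a comparable amount. Compound 4 is therefore expected near 1800 nM, range 700 nM to 4500 nM, a step of a 2.9-fold lower number from compound 2 to compound 4 (0.47 log units; beyond the scatter).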

Compound 4, concentration for 50% growth inhibition: 6000 nM
Compound 4: middle estimate off by 3.3-fold (0.52 log units), on the low side; the whole stated range lies below it.
By their numbers in this assay, from the lowest: compound 1; then compounds 2 and 4 (each within the scatter of the next).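

In this assay a substituent on the sulfonamide nitrogen does not by itself set a compound apart from the unsubstituted sulfonamide, since phenyl in place of hydrogen gives a 1.1-fold higher number from compound 2 to compound 4 (0.05 log units; within the scatter) and so no separation. The identity of the group matters at this position, as phenyl in place of cyclopentyl gives a 3.5-fold higher number from compound 1 to compound 4 (0.55 log units; beyond the scatter) and this lies beyond the scatter. Nothing available accounts for this difference between phenyl and cyclopentyl. Still open, from the compounds shown here alone, is whether cyclohexyl, a saturated ring of another size, or benzyl on the same nitrogen reads with compound 1 or with compound 2 and compound 4.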